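A few compounds are considered here, and "the series" means these few. Any claim that something is new, unique, unknown or untested is made for them only; others in the source may bear on it.

Compound 1 `CC1(C[C@@H](O)C(=O)N2N=CC[C@H]2C(=O)NCc2cc(Cl)ccc2-n2cnnn2)CC1` in an ADME assay on liver for metabolic stability, with Liver microsome (Homo sapiens) as the target, read by LC-MS, using microsomes; on this read-out lower numbers stand for slow clearance and higher numbers for fast clearance: < 12 mL.min-1.g-1.
Compound 2 `O=C(NCc1cc(Cl)ccc1-n1cnnn1)[C@@H]1C[C@@H]2C[C@@H]2N1C(=O)[C@H](O)c1cccc(Cl)c1` in this assay : > 500 mL.min-1.g-1.

For compound 1 the value < 12 mL.min-1.g-1 is a limit of the assay, not a number. Compound 2 gives > 500 mL.min-1.g-1, again a limit and not a number, so compound 2 stands at the limit of > 500 mL.min-1.g-1 in this assay, at which 1 of the 2 values shown sits. Going by the values given here, the two measured compounds sit at opposite limits, and no step between them can be sized. Compound 3 `O=C(NCc1cc(Cl)ccc1-n1cnnn1)[C@@H]1C[C@@H]2C[C@@H]2N1C(=O)[C@H](O)C1CCCCC1` differs from compound 2 by cyclohexyl in place of 3-chlorophenyl on a saturated chain carbon bound to a carbonyl carbon and an oxygen on a saturated carbon. Among the compounds with values here, no measured step covers this change, so its size is open; a move toward slower clearance is expected, of about an at least 2.5-fold lower number from compound 2 to compound 3 (0.39 log units; beyond the scatter). Compound 3 is therefore estimated at 200 mL.min-1.g-1, between 60 mL.min-1.g-1 and 500 mL.min-1.g-1.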

Compound 3, intrinsic clearance in microsomes: 150 mL.min-1.g-1
Compound 3: the middle estimate sits 1.3-fold (0.12 log units) above what was measured; the range from low to high includes it.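

In this assay, cyclohexyl in place of 3-chlorophenyl on a saturated chain carbon bound to a carbonyl carbon and an oxygen on a saturated carbon gives an at least 3.3-fold lower number from compound 2 to compound 3 (0.52 log units; beyond the scatter). This shows that the group at this position can move the read-out, and that compound 3 has a measured number on the shared core. The true size of the step stays unknown, because compound 2 stands at a limit of the assay: the limit of > 500 mL.min-1.g-1 in this assay, at which 1 of the 3 values shown sits.

From the compounds shown here alone, how an isopropyl group or a piperidine ring would read at this position remains open. So does whether the change would carry over to the core of compound 1.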